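Swapping an Ether Chain for Cyclobutyl on the Amine

The compounds below may be only part of what the source reports. "The series", "measured", "known", "first", "only" and "open" are said of these compounds alone.

Compound 1 `CCOCC(COCC)Nc1nc(C)nc2c(-c3ccc(OC)cc3C)c(C)nn12`: 19.3 nM
Compound 2 `CCN(CC)c1nc(C)nc2c(-c3cc(OC)c(OC)cc3Br)c(C)nn12`: 4.06 nM
Compound 3 `COCC(COC)Nc1nc(C)nc2c(-c3ccc(OC)cc3C)c(C)nn12`: 9.7 nM

All three compounds share one core and were tested in an assay on cell membranes for displacement of a labelled ligand from corticotropin-releasing factor receptor 1 (Rattus norvegicus); a higher number here means a weaker inhibitor, a lower number a stronger inhibitor. Among the measured compounds shown here, compound 3 stands second highest of the three numbers, and the only step that can be isolated, a 2.0-fold lower number from compound 1 to compound 3 (0.30 log units; within the scatter), shortens the ether chain on the ring nitrogen without leaving the scatter. Compound 2 carries both a different amine and a different aryl ring, so its gap to compound 3 cannot be tied to a single change.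

Compound 4 `COc1ccc(-c2c(C)nn3c(NC4CCC4)nc(C)nc23)c(C)c1` differs from compound 3 in one place: cyclobutyl in place of 2-methoxy-1-(methoxymethyl)ethyl on a nitrogen on an aromatic ring. For the measured compounds named here, no measured step covers this change directly; the one step available only shows that the chain can shrink with no effect beyond the scatter. For compound 4 a small shift or none is expected, with an estimate of 14 nM and a range from 4 nM to 50 nM. The expected step is a 1.4-fold higher number from compound 3 to compound 4 (0.16 log units; within the scatter).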

Compound 4, half-maximal inhibitory concentration: 24.6 nM
Compound 4: the middle estimate sits 1.8-fold (0.24 log units) below what was measured; the range from low to high includes it.
By their numbers in this assay, from the lowest: compound 2; then compounds 3, 1 and 4 (each within the scatter of the next, the first and the last beyond it).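

Cyclobutyl on this nitrogen costs a modest amount of binding against the 2-methoxy-1-(methoxymethyl)ethyl chain (a 2.5-fold higher number from compound 3 to compound 4 (0.40 log units; beyond the scatter)), the first single change here that leaves the scatter. Against the 2-ethoxy-1-(ethoxymethyl)ethyl chain, the same ring makes no clear difference (a 1.3-fold higher number from compound 1 to compound 4 (0.11 log units; within the scatter)), so the oxygen-bearing chains and this small carbon ring are not cleanly separated. Nothing available explains either result. Still open, going by these compounds, is how cyclopentyl or a plain propyl chain would behave on this nitrogen, and whether a methoxy group on the cyclobutyl ring would change the result.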